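Threonine to glutamine side chain on a chloropurine glycinamide

A few compounds are considered here, and "the series" means these few. Any claim that something is new, unique, unknown or untested is made for them only; others in the source may bear on it.

Measured so far:
compound 1, `O=C(O)[C@@H]1CCCN1C(=O)CN(c1nc(Cl)nc2[nH]cnc12)C1CC1`, 23.6%
compound 2, `C[C@@H](O)[C@H](NC(=O)CN(c1nc(Cl)nc2[nH]cnc12)C1CC1)C(=O)O`, 37.6%

Both compounds were tested in a functional assay on the whole organism (Tail, strain ICR) with Mus musculus as the target, in the tail flick test, with a stated time of 120 min, at a dose of 25 umol/kg by the oral route; a higher number here means a stronger effect of the compound at the dose given, a lower number a weaker effect. Compound 1 gives 23.6% and compound 2 gives 37.6%, so compound 2 stands highest of the two numbers shown, with compound 1 as its nearest neighbour. For the measured compounds named here, the only measured step, a number 14 percentage points higher from compound 1 to compound 2 (beyond the scatter), came with (1-carboxy-2-hydroxypropyl)amino in place of 2-carboxypyrrolidin-1-yl on a carbonyl carbon.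

Compound 3, `NC(=O)CC[C@H](NC(=O)CN(c1nc(Cl)nc2[nH]cnc12)C1CC1)C(=O)O`, has not yet been measured. It differs from compound 2 by 2-carbamoylethyl in place of 1-hydroxyethyl on a saturated chain carbon bound to an amide-type nitrogen and a carbonyl carbon. Going by the values given here, the measured step from compound 1 to compound 2 changed a different part of the molecule, so no measured step bears directly on this change; the two measured values only show the range the series has reached so far. Among the compounds with values here, with no step of the same kind to lean on, compound 3 is expected to land close to compound 2, with the estimated step of a number 2.6 percentage points lower from compound 2 to compound 3 (within the scatter) not beyond the scatter. For compound 3 the estimate in this assay is 35%, within 18% to 52%.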

Compound 3, a percentage reported as activity, at one dose (the size of the read-out at that dose, not a potency): 17.8%
Estimate against measurement, compound 3: 17.2 percentage points above, outside the stated range (below it).
By their numbers in this assay, from the lowest: compounds 3 and 1 (each within the scatter of the next); then compound 2.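

In this assay, the group on the saturated chain carbon bound to an amide-type nitrogen and a carbonyl carbon proves to matter: 2-carbamoylethyl in place of 1-hydroxyethyl gives a number 19.8 percentage points lower from compound 2 to compound 3 (beyond the scatter), even though the two groups have the same counts of hydrogen-bond donors and acceptors, so those counts do not tell them apart here. With compound 1 at 23.6% and compound 3 at 17.8%, these two values lie within the scatter of each other, which leaves compound 2 as the only one of the three clearly separated from the rest in this assay. Nothing measured here accounts for the drop in the read-out at this position.

The change swaps several features at once, including chain length, the hydroxyl for the terminal amide and a defined stereocentre in the side chain, so the compounds shown cannot say which of these goes with the lower number. Also open, from the compounds shown here alone, is how a hydroxymethyl group, a longer chain ending in a hydroxyl, or a chain ending in a carboxylic acid or an amine would read at this position.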